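Inverting the Ring Stereocentre of Compound 1

A few compounds are considered here, and "the series" means these few. Any claim that something is new, unique, unknown or untested is made for them only; others in the source may bear on it.

Compound 1 `COc1cc2nc(N3CCC[C@@H](NC(=O)c4ccco4)C3)nc(N)c2cc1OC` holds the second highest of three numbers in an assay on CHO cells for displacement of a labelled ligand from Alpha-1D adrenergic receptor (Homo sapiens), with a stated time of 30 min (on this read-out higher numbers stand for weaker inhibition and lower numbers for stronger inhibition), where compound 1 gives 37.2 nM. Among the measured compounds shown here, its nearest neighbour is compound 2 `COc1cc2nc(N3CCC[C@@H](N)C3)nc(N)c2cc1OC`, which in this assay gives 102 nM; the step of a 2.7-fold higher number from compound 1 to compound 2 (0.44 log units; beyond the scatter) is the only measured single-change step. Furthest away is compound 3 `COc1cc2nc(N3CCC[C@H](NC4=CC(=O)c5ccccc5C4=O)C3)nc(N)c2cc1OC`, which in this assay gives 2.14 nM. For the measured compounds named here, compound 4 `COc1cc2nc(N3CCC[C@H](NC(=O)c4ccco4)C3)nc(N)c2cc1OC` differs from compound 1 thus: the two compounds have the same atoms and bonds and differ only in configuration as drawn: 1 of 1 stereo elements differ; a stereocentre at a saturated ring carbon is drawn R in compound 1 and S in compound 4 No measured step covers a change of configuration on its own, and compound 3, drawn with the S configuration, also carries a different group, so its value can only be set beside that of compound 1. One therefore expects a step of a 1.2-fold lower number from compound 1 to compound 4 (0.09 log units; within the scatter) of uncertain direction. Compound 4 is estimated at 30 nM, with a range from 7 nM to 150 nM.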

Compound 4, inhibition constant: 0.331 nM
For compound 4 the middle estimate is 91-fold (1.96 log units) above the measured one; the measured number lies below the stated range.
By their numbers in this assay, from the lowest: compound 4; then compound 3; then compound 1; then compound 2.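

In this assay, among the compounds shown here, the configuration at the saturated ring carbon proves to be a far larger lever than the only earlier step, a 2.7-fold higher number from compound 1 to compound 2 (0.44 log units; beyond the scatter), could suggest: the inversion alone gives a 110-fold lower number from compound 1 to compound 4 (2.05 log units; beyond the scatter). With nothing else altered, the whole of this step belongs to that stereocentre: the fact that compounds 1 and 4 differ only in the configuration as drawn.

Going by these compounds, whether inversion has a similar effect with other groups on the amine nitrogen stays open, as compound 2 appears only as R and compound 3 only as S. How a benzoyl or an acetyl group would behave on the S configuration also remains unknown.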